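This account rests on a few compounds, and the source may have more. Where it says the series, first, only, none or still open, it means among the compounds named here.

In a functional assay on A549 cells (Homo sapiens) for cytotoxicity, read by MTT assay, with a stated time of 72 h (a lower number here means a stronger inhibitor, a higher number a weaker inhibitor), compound 1 `O=C(CN1CCN(c2nnc(Cc3ccccc3)c3ccccc23)CC1)Nc1ccc(F)c(F)c1` gives 10100 nM. Compound 2 `O=C(CN1CCN(c2nnc(Cc3ccncc3)c3ccccc23)CC1)Nc1ccc(F)c(Cl)c1` gives 12300 nM, within the usual scatter of compound 1, while compound 3 `O=C(CN1CCN(c2nnc(Cc3ccncc3)c3ccccc23)CC1)Nc1ccc(F)c(F)c1`, at 3790 nM, is the strongest of the three. Compound 4 `Cc1ccc(NC(=O)CN2CCN(c3nnc(Cc4ccccc4)c4ccccc34)CC2)c(C)c1` is still unmeasured: 2,4-dimethylphenyl in place of 3,4-difluorophenyl on an amide-type nitrogen. The closest evidence is a 3.2-fold lower number from compound 2 to compound 3 (0.51 log units; beyond the scatter), for fluoro in place of chloro on an aromatic carbon. The other measured step, a 2.7-fold lower number from compound 1 to compound 3 (0.43 log units; beyond the scatter), concerns pyridin-4-yl in place of phenyl elsewhere in the molecule and bears little on this change. Among the measured compounds shown here, no measured step swaps fluoro for methyl. A modest move towards a higher number in this assay is therefore expected, with the estimated step being a 1.3-fold higher number from compound 1 to compound 4 (0.11 log units; within the scatter). The estimate for compound 4 is 13000 nM, with an expected range of 5500 nM to 30000 nM.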

Compound 4, half-maximal inhibitory concentration: "not active" (no number reported)
No number was reported for compound 4; no gap can be computed for the estimate.
By their numbers in this assay, from the lowest: compound 3; then compounds 1 and 2 (each within the scatter of the next).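

Among the compounds shown here, compound 4 is reported as "not active" without a number, so no step from compound 1 to compound 4 can be read in this assay. Nothing shown here accounts for this result. From the compounds shown here alone, how far 2,4-dimethylphenyl in place of 3,4-difluorophenyl moves the number remains open.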